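Ester side-chain variation on a shared core

This account rests on a few compounds, and the source may have more. Where it says the series, first, only, none or still open, it means among the compounds named here.

Compound 1, `CC(C)=CC[C@@H](OC(=O)CCO)C1=CC(=O)c2c(O)ccc(O)c2C1=O`, gives 67600 nM in a functional assay on HeLa cells (Homo sapiens) for cytotoxicity, read by MTT assay; a lower number here means a stronger inhibitor, a higher number a weaker inhibitor.
Compound 2, `COCCO[C@H](CC=C(C)C)C1=CC(=O)c2c(O)ccc(O)c2C1=O`, gives 62400 nM in this assay.
Compound 3, `CCCCC(CC(=O)O[C@H](CC=C(C)C)C1=CC(=O)c2c(O)ccc(O)c2C1=O)OC(C)=O`, gives 73500 nM in this assay.

Compound 1 stands second highest of the three numbers in this assay: its nearest neighbour is compound 2, with a 1.1-fold lower number from compound 1 to compound 2 (0.03 log units; within the scatter), and its furthest is compound 3, with a 1.1-fold higher number from compound 1 to compound 3 (0.04 log units; within the scatter). Neither step reaches beyond the scatter, so the three compounds show no ordering that can be trusted.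

Compound 4, `CC(C)=CC[C@@H](OC(=O)CC(C)(O)C(C)C)C1=CC(=O)c2c(O)ccc(O)c2C1=O`, has not yet been measured. It differs from compound 1 in one place: 1-hydroxy-1,2-dimethylpropyl in place of hydroxymethyl on a saturated chain carbon bound to a carbonyl carbon. The step from compound 1 to compound 3 changes the same saturated chain carbon bound to a carbonyl carbon, and it stayed within the scatter; the step from compound 1 to compound 2 alters the whole group on the oxygen and also stayed within the scatter. Compound 4 is therefore expected to sit close to compound 1, with an estimated step of a 1.0-fold lower number from compound 1 to compound 4 (0.00 log units; within the scatter). Compound 4 is estimated at 67000 nM in this assay, with a range from 30000 nM to 150000 nM.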

Compound 4, half-maximal inhibitory concentration: 27700 nM
Beside the measured number, compound 4's estimate is 2.4-fold (0.38 log units) above it; the whole stated range lies above it.
By their numbers in this assay, from the lowest: compound 4; then compounds 2, 1 and 3 (each within the scatter of the next).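

In this assay the saturated chain carbon bound to a carbonyl carbon proves responsive to the group it carries: 1-hydroxy-1,2-dimethylpropyl in place of hydroxymethyl gives a 2.4-fold lower number from compound 1 to compound 4 (0.39 log units; beyond the scatter) and so moves beyond the scatter, which 1-acetoxypentyl at the same place did not do. Against that 1-acetoxypentyl group the change gives a 2.7-fold lower number from compound 3 to compound 4 (0.42 log units; beyond the scatter) and against the ether of compound 2 it gives a 2.3-fold lower number from compound 2 to compound 4 (0.35 log units; beyond the scatter) as well, so compound 4 alone stands apart from the other three, though each of these steps is modest. Nothing given here accounts for this difference.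

The compounds shown leave open whether the hydroxyl or the branched carbons of the new group carry the step. A plain 1,2-dimethylpropyl group at this place would separate the two, while an amine or a carboxylic acid there would test how far the hydroxyl can be replaced.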